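The source may hold more compounds than are shown below. What is called first, only, known or untested is meant among the compounds shown, and "the series" means these compounds.

In a functional assay on MDA-MB-436 cells (Homo sapiens) for antiproliferative activity, read by MTT assay, with a stated time of 48 h (on this read-out higher numbers stand for weaker inhibition and lower numbers for stronger inhibition), compound 1 (`CCCNC(=O)N1CCN(c2ncnc3sc(-c4ccc(N5CCN(C)CC5)cc4)cc23)CC1`) gives 12400 nM, and compound 2 (`CN1CCN(c2ccc(-c3cc4c(N5CCN(C(=O)Nc6ccccc6F)CC5)ncnc4s3)cc2)CC1`) gives 14300 nM. Only these two numbers are available so far, and compound 2 stands within the scatter of compound 1.

The next compound is compound 3 (`CN1CCN(c2ccc(-c3cc4c(N5CCN(C(=O)Nc6cccc(F)c6)CC5)ncnc4s3)cc2)CC1`). It keeps the shared core of compound 2 and differs in one place, on an amide-type nitrogen: 3-fluorophenyl in place of 2-fluorophenyl on an amide-type nitrogen. In words, 3-fluorophenyl takes the place of 2-fluorophenyl.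

Among the measured compounds shown here, one measured step bears on this, and only indirectly. Replacing propyl with 2-fluorophenyl on the same nitrogen gave a 1.2-fold higher number from compound 1 to compound 2 (0.06 log units; within the scatter). For the measured compounds named here, no measured pair tests a move of the fluorine itself, so the data offer no direct guide to this change. With that single step inside the scatter, no shift beyond the scatter is expected in this assay, and no direction is favoured. The expected outcome is a 1.1-fold lower number from compound 2 to compound 3 (0.03 log units; within the scatter), which is a step of no real size. For compound 3 the estimated value is 13500 nM, with an expected range of 7000 nM to 26000 nM.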

Compound 3, half-maximal inhibitory concentration: 18300 nM
Compound 3: the middle estimate sits 1.4-fold (0.13 log units) below what was measured, within the range that was stated.
By their numbers in this assay, from the lowest: compounds 1, 2 and 3 (each within the scatter of the next).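

In this assay the first measured move of the fluorine itself, 3-fluorophenyl in place of 2-fluorophenyl on an amide-type nitrogen, gives a 1.3-fold higher number from compound 2 to compound 3 (0.11 log units; within the scatter) and so does not separate the two fluorophenyl groups at this position. The comparison with the chain holds for the new group as well: 3-fluorophenyl in place of propyl gives a 1.5-fold higher number from compound 1 to compound 3 (0.17 log units; within the scatter) and so adds a second aryl group that stays within the scatter of propyl. All three compounds therefore lie within the scatter of one another, and no measurement at hand explains why this position shows so little response in this cell assay.

Still open, from the compounds shown here alone, is whether any group on this nitrogen can give a number beyond the scatter of these three, for instance a longer chain such as hexyl, 4-fluorophenyl, or a phenyl ring carrying a carboxylic acid. Also open, going by these compounds, is whether the same insensitivity to the position of the fluorine would hold with a different group in place of the 4-methylpiperazinyl-bearing phenyl, which stays fixed in all three compounds.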